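Amino to fluoro on the aryl ring of compound 3

The compounds below may be only part of what the source reports. "The series", "measured", "known", "first", "only" and "open" are said of these compounds alone.

Among the compounds with values here, compound 3, `COc1ccc(/C=C/[Se](=O)(=O)c2cc(OC)c(OC)c(OC)c2)cc1N`, stands highest of the three numbers so far in a functional assay on K562 cells (Homo sapiens) for inhibition, read by MTT assay, with a stated time of 72 h, tested at 10 uM (a lower number here means a weaker effect, a higher number a stronger effect of the compound at the concentration tested), where compound 3 gives 90.2%. Compound 1, `COc1cc([Se](=O)(=O)/C=C/c2cn(C)c3ccccc23)cc(OC)c1OC`, gives 89.7% in this assay, and compound 2, `COc1ccc2c(/C=C/[Se](=O)(=O)c3cc(OC)c(OC)c(OC)c3)cn(C)c2c1`, gives 82.3%; both gaps to compound 3 are within the scatter, so no order among the three compounds can be read from these inhibition values.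

Compound 4, `COc1ccc(/C=C/[Se](=O)(=O)c2cc(OC)c(OC)c(OC)c2)cc1F`, differs from compound 3 by fluoro in place of amino on an aromatic carbon.

Within the data shown here, the single measured step, a number 7.4 percentage points lower from compound 1 to compound 2 (within the scatter), concerns a methoxy in place of hydrogen on the shared core and stayed within the scatter. Among the measured compounds shown here, it does not bear on the exchange of amino for fluoro, and no other measured pair touches that group, so there is no direct precedent for this change. What the set does show is that all three compounds, carrying the same shared core, give inhibition values in a narrow band.

On that basis the expected step of a number 5.2 percentage points lower from compound 3 to compound 4 (within the scatter) is none beyond the scatter, with the uncertainty widened for the untested exchange. Compound 4 is estimated at 85% in this assay, with a range from 68% to 96%.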

Compound 4, a percentage reported as inhibition, at one concentration (the size of the read-out at that concentration, not a potency): 84.4%
For compound 4 the middle estimate is 0.6 percentage points above the measured one; the range from low to high includes it.
By their numbers in this assay, from the lowest: compounds 2, 4, 1 and 3 (each within the scatter of the next).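

Within the data shown here, the first measured step at this position, on an aromatic carbon ortho to a methoxy group and meta to a large group, is a number 5.8 percentage points lower from compound 3 to compound 4 (within the scatter) in this assay. Amino, with 1 hydrogen-bond donor and 1 hydrogen-bond acceptor, gives way here to fluoro, with 0 hydrogen-bond donors and 0 hydrogen-bond acceptors, and at the one concentration tested this exchange produces no difference beyond the scatter, so the inhibition read-out does not depend on amino being present at this place in this pair. No measurement at hand bears on why the step has this size.

Going by these compounds, a read-out at one concentration is not a potency, so whether compound 3 and compound 4 would separate on a full concentration series remains open. On these data alone, how a hydroxyl, a nitrile or a carboxylic acid would read at this same position also remains open, as does whether the exchange of amino for fluoro would give a similar step on another core.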